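Compound 4: One Stereocentre Redrawn

A few compounds are considered here, and "the series" means these few. Any claim that something is new, unique, unknown or untested is made for them only; others in the source may bear on it.

Four close relatives share one core and differ only in the chain that carries the carboxylic acid: compound 1 `CC(CCCCOc1ccccc1CN(C)C(=O)c1ccc(-c2ccco2)cc1)C(=O)O`, compound 2 `C[C@@H](CCCOc1ccccc1CN(C)C(=O)c1ccc(-c2ccco2)cc1)CC(=O)O`, compound 3 `CN(Cc1ccccc1OCCC[C@@H]1C[C@@H]1C(=O)O)C(=O)c1ccc(-c2ccco2)cc1` and compound 4 `CN(Cc1ccccc1OCCC[C@@H]1C[C@H]1C(=O)O)C(=O)c1ccc(-c2ccco2)cc1`. In an ADME assay on the whole organism (strain CD-1) for pharmacokinetics, with Mus musculus as the target, at a dose of 3 mg/kg by the intravenous route (on this read-out lower numbers stand for lower exposure and higher numbers for higher exposure at the dose given), compound 1 gives 11400 ng.h/mL, compound 2 gives 30800 ng.h/mL and compound 3 gives 30100 ng.h/mL. Compound 3 therefore stands level with compound 2, and both lie clearly above compound 1.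

Compound 4 keeps the 2-carboxycyclopropyl group of compound 3, and the change is purely one of spatial arrangement: the two compounds have the same atoms and bonds and differ only in configuration as drawn: 1 of 2 stereo elements differ; a stereocentre at a saturated ring carbon is drawn S in compound 3 and R in compound 4. Nothing leaves and nothing enters. Replacing the 2-carboxypropyl group of compound 1 gave modest steps, a 2.7-fold higher number from compound 1 to compound 2 (0.43 log units; beyond the scatter) and a 2.6-fold higher number from compound 1 to compound 3 (0.42 log units; beyond the scatter). Exchanging the group of compound 2 for 2-carboxycyclopropyl gave a 1.0-fold lower number from compound 2 to compound 3 (0.01 log units; within the scatter), which is within the scatter. None of these steps changes configuration alone, so they offer only indirect guidance, and a modest move in either direction cannot be ruled out. Since even changes of the whole group moved the numbers only modestly, no step beyond the scatter is expected in this assay. The expected step is a 1.1-fold lower number from compound 3 to compound 4 (0.05 log units; within the scatter). The estimate for compound 4 is 27000 ng.h/mL, within a range from 12000 ng.h/mL to 60000 ng.h/mL.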

Compound 4, area under the concentration-time curve: 40500 ng.h/mL
Beside the measured number, compound 4's estimate is 1.5-fold (0.18 log units) below it; the measured number falls inside the stated range.
By their numbers in this assay, from the lowest: compound 1; then compounds 3, 2 and 4 (each within the scatter of the next).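

In this assay, among these compounds, a 1.3-fold higher number from compound 3 to compound 4 (0.13 log units; within the scatter) is the first step here that tests spatial arrangement alone at this saturated ring carbon, and it shows no effect that can be told apart from the scatter, in a comparison with nothing else altered: the fact that compounds 3 and 4 differ only in the configuration as drawn. The second drawn form of the 2-carboxycyclopropyl group also matches the open chain of compound 2, with a 1.3-fold higher number from compound 2 to compound 4 (0.12 log units; within the scatter), so neither drawn form separates from that 1-(carboxymethyl)ethyl compound. Against the 2-carboxypropyl group of compound 1, the change holds up with a 3.6-fold higher number from compound 1 to compound 4 (0.55 log units; beyond the scatter), so the gain seen earlier with compound 3 does not depend on how this one stereocentre is drawn.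

Only one of the two stereo elements changes between compound 3 and compound 4, so the compounds shown leave open what happens when the other ring carbon is redrawn, or when both are. They also leave open whether the same exposure would hold with a 2-carboxycyclobutyl group on this chain, or with a tetrazole in place of the carboxylic acid.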